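One Fluoro Less: What Compound 4 Might Need

The source may hold more compounds than are shown below. What is called first, only, known or untested is meant among the compounds shown, and "the series" means these compounds.

Compound 1 `O=C(/C=C1\CCc2cc(F)cc(F)c21)NC1CC1`: 81 mg/kg
Compound 2 `CC(C)NC(=O)/C=C1\CCc2ccc(F)cc21`: > 100 mg/kg (a limit of the assay)
Compound 3 `CC(C)NC(=O)/C=C1\CCc2c(F)cc(F)cc21`: 76 mg/kg

All three were tested in a functional assay on the whole organism with Mus musculus as the target, in the rotarod test; on this read-out higher numbers stand for an effect only at larger amounts of compound and lower numbers for an effect already at smaller amounts. Compound 1 gives 81 mg/kg and compound 3 gives 76 mg/kg, two values that lie within the usual scatter of each other. Compound 2 gives > 100 mg/kg, which is a limit of the assay and not a number. Compound 3 and compound 2 differ in one place only: hydrogen in place of fluoro on an aromatic carbon. That step is an at least 1.3-fold higher number from compound 3 to compound 2 (0.11 log units; that floor lies within the scatter); it ends at the limit of > 100 mg/kg in this assay, at which 1 of the 3 values shown sits, so only its floor is known. Compound 1 and compound 3 differ in more than one place, and the difference between the two cores is not broken down here. Compound 4 `O=C(/C=C1\CCc2cc(F)ccc21)NC1CC1` has not yet been measured; it arises from compound 1 by the same change, (hydrogen in place of fluoro on an aromatic carbon). In this assay the step from compound 1 to compound 4 is expected to be a 1.4-fold higher number from compound 1 to compound 4 (0.15 log units; within the scatter), because the same change elsewhere gave an at least 1.3-fold higher number from compound 3 to compound 2 (0.11 log units; that floor lies within the scatter). On that basis compound 4 is expected to give 115 mg/kg in this assay, roughly between 60 mg/kg and 250 mg/kg, with a real chance that only a limit is reported.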

Compound 4, dose for half-maximal effect: 193 mg/kg
The estimate for compound 4 lay 1.7-fold (0.22 log units) below the measured number; the range from low to high includes it.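

In this assay, putting hydrogen in place of the fluoro group on the core of compound 1 gives a 2.4-fold higher number from compound 1 to compound 4 (0.38 log units; beyond the scatter), a modest step that lies beyond the usual scatter, so compound 4 needs a larger dose to reach the same effect. The same change on the other core can be set beside this result only in part: the same change on two cores in this assay, an at least 1.3-fold higher number (0.11 log units; that floor lies within the scatter) from compound 3 to compound 2 and a 2.4-fold higher number (0.38 log units; beyond the scatter) from compound 1 to compound 4; the limit leaves it open whether they differ. From the compounds shown here alone, compound 2 has a limit of the assay and not a number, so the size of the change on its core remains unknown, and two pairs of compounds cannot establish a rule for the whole series: the limit of > 100 mg/kg in this assay, at which 1 of the 4 values shown sits.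

The compounds shown leave open whether a group other than hydrogen, such as a chlorine atom or a methoxy group, would behave differently at the place the fluoro group leaves. They also leave open how the same change would read with a longer chain on the amide nitrogen.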